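A New Group on the Amide Nitrogen of Compound 1

The source may hold more compounds than are shown below. What is called first, only, known or untested is meant among the compounds shown, and "the series" means these compounds.

In a functional assay on HUVEC cells (Homo sapiens) for inhibition, with a stated time of 4 days (a higher number here means a weaker inhibitor, a lower number a stronger inhibitor), compound 1 `COc1ccc(C(N)=O)cc1/C=C/c1ccc(Cl)cc1` gives 87 nM and stands lowest of the three measured compounds. Compound 2 `COc1ccc(/C=C/c2cc(C(N)=O)ccc2OC)cc1` gives 8800 nM and compound 3 `COc1ccc(C(N)=O)cc1/C=C/c1ccc(Cl)cc1Cl` gives 2600 nM in comparison. Among the measured compounds shown here, the unmeasured compound 4 `COc1ccc(C(=O)NC(CO)CO)cc1/C=C/c1ccc(Cl)cc1` carries 2-hydroxy-1-(hydroxymethyl)ethyl in place of hydrogen on an amide-type nitrogen as its one change. Neither measured step involves that nitrogen, so they bear on it only indirectly. Both are large rises, with a 100-fold higher number from compound 1 to compound 2 (2.00 log units; beyond the scatter) for methoxy in place of chloro and a 30-fold higher number from compound 1 to compound 3 (1.48 log units; beyond the scatter) for chloro in place of hydrogen on an aromatic carbon. A smaller rise is expected here, with an estimated 4.0-fold higher number from compound 1 to compound 4 (0.60 log units; beyond the scatter) as the step. For compound 4 the estimate is 350 nM with an expected range of 60 nM to 2500 nM in this assay here.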

Compound 4, half-maximal inhibitory concentration in the HUVEC assay: 1500 nM
Compound 4: middle estimate off by 4.3-fold (0.63 log units), on the low side; the range from low to high includes it.
By their numbers in the HUVEC assay, from the lowest: compound 1; then compounds 4 and 3 (each within the scatter of the next); then compound 2.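

Among the compounds shown here, the amide nitrogen, untouched by the earlier steps, proves just as sensitive as the aromatic carbons: in the HUVEC assay, putting 2-hydroxy-1-(hydroxymethyl)ethyl in place of the amide hydrogen gives a 17-fold higher number from compound 1 to compound 4 (1.24 log units; beyond the scatter). In a physicochemical assay for solubility, read by HPLC, in simulated intestinal fluid, with a stated time of 2 h, tested at 10 mM (on this read-out higher numbers stand for higher solubility and lower numbers for lower solubility), compound 1 gives 16 ug/mL and compound 4 gives 251 ug/mL. Unlike those steps, this change also has a measured gain on the other side, in the physicochemical assay: the measured solubility of compound 1, 16 ug/mL, and of compound 4, 251 ug/mL, a 16-fold higher number (1.20 log units; beyond the scatter)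

On these data alone, whether a methyl group or a chain ending in an amine or a carboxylic acid on this nitrogen would keep the number of compound 1 while raising solubility remains open. A single change also cannot separate the effect of the chain's size from that of its hydroxyl groups.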